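Iodo in place of nitro: working notes on compound 4

The source may hold more compounds than are shown below. What is called first, only, known or untested is meant among the compounds shown, and "the series" means these compounds.

In a functional assay on U-87MG ATCC cells (Homo sapiens) for cytotoxicity, read by MTT assay, with a stated time of 48 h (a lower number here means a stronger inhibitor, a higher number a weaker inhibitor), compound 1 `CC(=NNC(=S)Nc1ccccc1[N+](=O)[O-])c1ccccn1` gives 4.3 nM. Compound 2 `C/C(=N/NC(=S)Nc1ccccc1[N+](=O)[O-])c1ccccn1` gives 4.3 nM and compound 3 `C/C(=N\NC(=S)Nc1ccccc1[N+](=O)[O-])c1ccccn1` gives 4.3 nM, so compound 1 stands level with both.

The next compound to be measured, compound 4 `CC(=NNC(=S)Nc1ccccc1I)c1ccccn1`, keeps the core of compound 1 and alters one group: iodo in place of nitro on an aromatic carbon. In words, this is iodo in place of nitro on an aromatic carbon, ortho to a large group.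

The measured steps are no change at the digits printed from compound 1 to compound 2 (within the scatter), no change at the digits printed from compound 1 to compound 3 (within the scatter) and no change at the digits printed from compound 2 to compound 3 (within the scatter). What separates these compounds is the fact that one of compounds 1 and 2 is drawn with a defined configuration and the other without, at the place where they differ, the fact that one of compounds 1 and 3 is drawn with a defined configuration and the other without, at the place where they differ and (the fact that compounds 2 and 3 differ only in the configuration as drawn). None of the three steps touches the place that changes in compound 4, so they give no direct size or direction for this replacement.

The expectation therefore starts from compound 1 at 4.3 nM, with a wide margin and only a slight leaning towards weaker inhibition in this assay. The estimated change is a 1.6-fold higher number from compound 1 to compound 4 (0.21 log units; within the scatter), and no step beyond the scatter is firmly expected.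

For compound 4 the expected value is 7 nM, with an estimated range from 1.5 nM to 35 nM.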

Compound 4, half-maximal inhibitory concentration: 6.1 nM
The estimate for compound 4 lay 1.1-fold (0.06 log units) above the measured number, and the stated range covers the measured number.
By their numbers in this assay, from the lowest: compounds 1, 2, 3 and 4 (each within the scatter of the next).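

In this assay, iodo in place of nitro on an aromatic carbon, ortho to a large group, gives a 1.4-fold higher number from compound 1 to compound 4 (0.15 log units; within the scatter), and this is the only step shown that touches this position, as compounds 1, 2 and 3 all carry nitro there. The position therefore takes a replacement of nitro by iodo without a step beyond the scatter, even though nitro has 2 hydrogen-bond acceptors and iodo has 0, so in this pair the nitro group is not required for a number at this level. The comparisons among compounds 1, 2 and 3 concern only the configuration drawn at the double bond, and nothing shown gives a reason for the result at this position.

With only nitro and iodo shown at this place, it remains open whether the level holds for a quite different group there, such as an amine, a carboxylic acid or a methoxy group. Going by these compounds, compound 4 is also drawn without a configuration at the double bond, so it remains open how its separately drawn E and Z forms would compare in this assay.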